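The source may hold more compounds than are shown below. What is called first, only, known or untested is meant among the compounds shown, and "the series" means these compounds.

Working notes on the series. Compound 1 is `Cc1cc(-c2cccc(C#N)c2)cn2c(CSCCc3ccccc3)cnc12`. In an ADME assay on HEL cells (Homo sapiens) for cytotoxicity, with a stated time of 3 days (a lower number here means that less compound is tolerated, a higher number that more compound is tolerated), compound 1 gives > 100 ug/mL, which is a limit of the assay and not a number. Within the data shown here, the only other measured member, compound 2, is `Cc1cc(I)c2ncc(CSCCc3ccccc3)n2c1`; in this assay compound 2 gives >= 4 ug/mL, again a limit rather than a number. Among the measured compounds shown here, compound 1 thus stands at the limit of > 100 ug/mL in this assay, at which 1 of the 2 values shown sits, while the other value sits at the limit of >= 4 ug/mL in this assay, at which 1 of the 2 values shown sits; no measured step between the two is available, so nothing can be said of their order.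

The compound followed next is compound 3, `Cc1cc(-c2cccc(O)c2)cn2c(CSCCc3ccccc3)cnc12`. It differs from compound 1 as follows: hydroxy in place of cyano on an aromatic carbon. For the measured compounds named here, no measured step covers this change, so the expectation rests on compound 1 alone. Because compound 1 sits at the limit of > 100 ug/mL in this assay, at which 1 of the 2 values shown sits, the expected step in this assay is a number no higher from compound 1 to compound 3 (the limit leaves the size open), none beyond the scatter. Compound 3 is therefore estimated to give in this assay about 100 ug/mL, with an expected range from 50 ug/mL to 200 ug/mL, and most likely again only a limit.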

Compound 3, minimum cytotoxic concentration: 20 ug/mL
Beside the measured number, compound 3's estimate is 5.0-fold (0.70 log units) above it; the whole stated range lies above it.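

Among these compounds, the exchange of 3-cyanophenyl for 3-hydroxyphenyl gives the first readable step in this assay, which is an at least 5.0-fold lower number from compound 1 to compound 3 (0.69 log units; beyond the scatter). The group on this aromatic carbon, meta to a large group, therefore makes a difference beyond the scatter to how much compound the HEL cells tolerate, and the hydroxy group is on the less tolerated side of that difference. The step has a lower bound only and no upper one, because the starting point is a limit of the assay and not a number, held by compound 1: the limit of > 100 ug/mL in this assay, at which 1 of the 3 values shown sits.

The compounds shown leave open whether the lower number is particular to hydroxy or would also appear with other groups at this place, such as an amine, a methoxy group or a carboxylic acid. They also give no measured property that would explain the step, and they do not show whether the same exchange would give a similar step elsewhere on this ring.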